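The compounds below may be only part of what the source reports. "The series", "measured", "known", "first", "only" and "open" are said of these compounds alone.

Measured compounds:
- compound 1 `Cc1cccc(NC(=O)CSc2nnc(-c3ccoc3C)n2Cc2ccco2)c1C`; in a functional assay on CHO cells for antagonist activity at Orexin receptor type 2 (Homo sapiens), read by FLIPR and calcium flux (on this read-out lower numbers stand for stronger inhibition and higher numbers for weaker inhibition), compound 1 gives > 15800 nM, which is a limit of the assay and not a number.
- compound 2 `Cc1occc1-c1nnc(SCC(=O)Nc2ccc(F)c(Cl)c2)n1Cc1ccco1`; compound 2 gives 39.8 nM.
- compound 3 `Cc1cccc(NC(=O)CSc2nnc(-c3ccoc3C)n2Cc2ccco2)c1`; compound 3 gives 50.1 nM.

Going by the values given here, compound 1 is the one value that sits at the limit (the limit of > 15800 nM in this assay, at which 1 of the 3 values shown sits), so its true number is known only as lying beyond that bound. Compounds 2 and 3 give numbers close to each other; their gap, a 1.3-fold higher number from compound 2 to compound 3 (0.10 log units; within the scatter), lies within the scatter.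

The step under consideration leads from compound 1 to compound 4 `Cc1occc1-c1nnc(SCC(=O)Nc2cccc(F)c2)n1Cc1ccco1`. The change is 3-fluorophenyl in place of 2,3-dimethylphenyl on an amide-type nitrogen.

Two measured steps start from compound 1. Replacing the 2,3-dimethylphenyl group with 3-chloro-4-fluorophenyl gave an at least 390-fold lower number from compound 1 to compound 2 (2.59 log units; beyond the scatter). Removing a single methyl, hydrogen in place of methyl on an aromatic carbon, gave an at least 310-fold lower number from compound 1 to compound 3 (2.49 log units; beyond the scatter). Among the compounds with values here, both changes leave the amide-bound phenyl without the two adjacent methyls and both land in the same low range, so the pattern on these three compounds is that the 2,3-dimethylphenyl group itself carries the weak result; no measured compound runs against this.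

The 3-fluorophenyl group in compound 4 also lacks both methyls, and its fluorine matches one substituent seen in compound 2. A large drop is therefore expected, of about an at least 260-fold lower number from compound 1 to compound 4 (2.42 log units; beyond the scatter), landing near compounds 2 and 3. The expected value for compound 4 in this assay is 60 nM, with a range from 20 nM to 300 nM.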

Compound 4, inhibition constant: 501 nM
Beside the measured number, compound 4's estimate is 8.4-fold (0.92 log units) below it; measured number outside the range, above it.
By their numbers in this assay, from the lowest: compounds 2 and 3 (each within the scatter of the next); then compound 4. At a limit, above all of these: compound 1.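

On the amide-type nitrogen in this assay, 3-fluorophenyl in place of 2,3-dimethylphenyl gives an at least 31-fold lower number from compound 1 to compound 4 (1.49 log units; beyond the scatter), so the earlier link between the 2,3-dimethylphenyl group and the weak result still holds, but losing that group does not by itself bring a compound to the level of compound 2 and compound 3. The rest of the phenyl substitution also counts at this position: fluoro in place of methyl on an aromatic carbon gives a 10-fold higher number from compound 3 to compound 4 (1.00 log units; beyond the scatter), and 3-fluorophenyl in place of 3-chloro-4-fluorophenyl gives a 13-fold higher number from compound 2 to compound 4 (1.10 log units; beyond the scatter). Compound 1 remains a limit of the assay and not a number, so its step to compound 4 is only a bound: the limit of > 15800 nM in this assay, at which 1 of the 4 values shown sits.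

The compounds shown leave open how much of the gap to compound 2 belongs to the chlorine of the 3-chloro-4-fluorophenyl group, which a chlorophenyl group carrying no fluorine would help to separate. Also open, as far as these compounds go, is whether other groups on this nitrogen, such as methoxyphenyl, aminophenyl or a non-aromatic cyclohexyl, would stay near compound 3 or fall towards compound 4.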